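The source may report more compounds than this note shows. Statements on the series, on what has been measured and on what is new or still open speak of the compounds shown alone.

Working notes on the series. In a functional assay (aorta) with Oryctolagus cuniculus as the target (a lower number here means tighter binding, a higher number weaker binding), compound 1 (`COc1cc(C(=O)O)ccc1OCCCN1CCC(C(c2ccc(F)cc2)c2ccc(F)cc2)CC1`) gives 79.4 nM and compound 2 (`N#Cc1ccc(OCCCN2CCC(C(c3ccc(F)cc3)c3ccc(F)cc3)CC2)cc1`) gives 5.01 nM, so compound 2 holds the lower of the two numbers. Compound 3 (`Fc1ccc(C(c2ccc(F)cc2)C2CCN(CCCOc3ccc(Br)cc3)CC2)cc1`) has not yet been measured. It differs from compound 2 at one place, with bromo in place of cyano on an aromatic carbon, para to a large group: bromo in place of cyano on an aromatic carbon.

For the measured compounds named here, only one measured step is available, a 16-fold lower number from compound 1 to compound 2 (1.20 log units; beyond the scatter), which lies beyond the scatter. That step replaces a phenyl carrying both carboxy and methoxy groups with 4-cyanophenyl, so it bears only loosely on the present exchange. It shows that this assay can respond to changes on this ring, but it does not show the effect of swapping one group for another at this place. Going by the values given here, no measured pair isolates that exchange.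

With no closer evidence, a step within the scatter and of no clear direction is expected, starting from compound 2 at 5.01 nM. The expected step is a 1.2-fold higher number from compound 2 to compound 3 (0.08 log units; within the scatter). For compound 3, the estimated value is 6 nM, with an expected range from 2 nM to 20 nM.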

Compound 3, dissociation constant: 1.59 nM
The estimate for compound 3 lay 3.8-fold (0.58 log units) above the measured number; the measured number lies below the stated range.
By their numbers in this assay, from the lowest: compound 3; then compound 2; then compound 1.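

In this assay, for the compounds shown here, the exchange at this place is now isolated for the first time: bromo in place of cyano on an aromatic carbon, para to a large group, gives a 3.2-fold lower number from compound 2 to compound 3 (0.50 log units; beyond the scatter) with the rest of the structure unchanged. A single group at this place therefore moves the number beyond the scatter, which the earlier step could not show, as it changed the whole substituted ring at once. The wider ring exchange now has a second case, a 50-fold lower number from compound 1 to compound 3 (1.70 log units; beyond the scatter) alongside a 16-fold lower number from compound 1 to compound 2 (1.20 log units; beyond the scatter) in the same direction, and compound 3 holds the lowest of the three numbers, with its steps to both others beyond the scatter, while nothing measured here bears on the cause of these steps.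

The compounds shown leave open whether the lower number is particular to bromo or would also be seen with chloro, fluoro or methyl at this place, or with only hydrogen there. They also leave open how a carboxylic acid or a methoxy group alone would read on this ring, as compound 1 carries the two together.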